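Halogen swap on the aryl ring: compound 3 to compound 4

The source may report more compounds than this note shows. Statements on the series, on what has been measured and on what is new or still open speak of the compounds shown alone.

Measured so far:
- compound 2 `CCN1CCC/C1=N\C(=O)Nc1cccc(Cl)c1`: 15 mg/kg
- compound 3 `CN1CCC/C1=N\C(=O)Nc1cccc(Cl)c1`: 15 mg/kg
- compound 1 `CC(C)c1cccc(C(C)C)c1NC(=O)/N=C1\CCCN1C`: "not determined" (no result reported)

In a functional assay on the whole organism with Rattus norvegicus as the target, with a stated time of 5 days (a lower number here means that less compound is needed, a higher number that more compound is needed for the effect), compound 3 gives 15 mg/kg. Among the compounds with values here, its nearest neighbour is compound 2, which gives 15 mg/kg; the only measured step, no change at the digits printed from compound 2 to compound 3 (within the scatter), concerns hydrogen in place of methyl on a saturated chain carbon bound to an amine nitrogen in a ring. Compound 1 carries no result.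

Compound 4 `CN1CCC/C1=N\C(=O)Nc1cccc(F)c1` differs from compound 3 by fluoro in place of chloro on an aromatic carbon. Within the data shown here, no measured step touches the group on the aromatic carbon, so nothing bears directly on this change; the one step recorded lies elsewhere and showed no change. The step of a 1.3-fold higher number from compound 3 to compound 4 (0.12 log units; within the scatter) is therefore expected to stay within the scatter, with no direction favoured. Compound 4 is estimated at 20 mg/kg, range 8 mg/kg to 50 mg/kg.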

Compound 4, minimum effective dose: 25 mg/kg
Compound 4: the middle estimate sits 1.3-fold (0.10 log units) below what was measured; measured number inside the range.
By their numbers in this assay, from the lowest: compounds 2, 3 and 4 (each within the scatter of the next).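

In this assay, the swap on the aromatic carbon gives a 1.7-fold higher number from compound 3 to compound 4 (0.22 log units; within the scatter), so chloro and fluoro at this place cannot be told apart. Within the data shown here, this is the first reading on the aromatic ring, as the earlier step concerned only the saturated chain carbon bound to the ring amine nitrogen. No available evidence bears on this result.

Only two halogens are shown at this place, so it remains open whether a methoxy, a nitrile or an amine there would stay within the scatter of compound 3. The same question stands for bromo.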